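The compounds below may be only part of what the source reports. "The series", "measured", "known", "first", "only" and "open" are said of these compounds alone.

Measured so far in a functional assay on PC-3 cells (Homo sapiens) for cytotoxicity, read by MTT assay, with a stated time of 72 h; on this read-out higher numbers stand for weaker inhibition and lower numbers for stronger inhibition:
- compound 1 `CNC(=O)c1cc(Oc2ccc(C3=NNC(c4cccc(Br)c4)C3)cc2)ccn1` (3540 nM)
- compound 2 `CNC(=O)c1cc(Oc2ccc(C3=NNC(c4ccc(F)cc4Cl)C3)cc2)ccn1` (24300 nM)

Compound 2 has the higher number of the pair (24300 nM) and is therefore the weaker inhibitor of the two, with compound 1 as its nearest neighbour. Next in the series is compound 3 `CNC(=O)c1cc(Oc2ccc(C3=NNC(c4ccc([N+](=O)[O-])cc4)C3)cc2)ccn1`, which carries 4-nitrophenyl in place of 2-chloro-4-fluorophenyl on a saturated ring carbon. Going by the values given here, only one measured step bears on this change, a swap of groups at the same place (a 6.9-fold higher number from compound 1 to compound 2 (0.84 log units; beyond the scatter)), and it is modest in size. Among the compounds with values here, no compound with a 4-nitrophenyl group has a measured value yet, so the direction is uncertain. With compound 2 at the top of a very short range (24300 nM), a step of similar or smaller size towards lower numbers is expected in this assay, though a step towards higher numbers cannot be excluded. The expected change is a 2.7-fold lower number from compound 2 to compound 3 (0.43 log units; beyond the scatter) as a working estimate. For compound 3 the estimated value is 9000 nM with an expected range from 2500 nM to 30000 nM as the working bounds.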

Compound 3, half-maximal inhibitory concentration: > 50000 nM
Compound 3: only a limit was reported (the forecaster's own chance of this, stated with the estimate: 8%); middle value at least 5.5-fold (0.74 log units) from the limit.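

In this assay, compound 3 is reported only as a limit and not as a number: the limit of > 50000 nM in this assay, at which 1 of the 3 values shown sits.
Placing 4-nitrophenyl on the saturated ring carbon instead of 2-chloro-4-fluorophenyl gives an at least 2.0-fold higher number from compound 2 to compound 3 (0.31 log units; beyond the scatter), and the comparison with the 3-bromophenyl group gives an at least 14-fold higher number from compound 1 to compound 3 (1.14 log units; beyond the scatter). The earlier pair showed sensitivity to the group at this carbon only between two halogen-bearing phenyl groups; with a nitro-bearing phenyl group, the range widens, and compound 1 remains the strongest inhibitor of the three, its steps to both others lying beyond the scatter.

The three groups differ in both the substituents and where they sit on the phenyl ring, so the compounds shown do not separate the identity of a substituent from its location. A 3-nitrophenyl or 4-bromophenyl group would address that separation at this carbon, while an unsubstituted phenyl or a 4-aminophenyl group would show whether the low number of compound 1 depends on a halogen at all.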